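Replacing thiophen-3-yl with 1-methyl-1H-pyrazol-5-yl on the amide

The compounds below may be only part of what the source reports. "The series", "measured", "known", "first", "only" and "open" are said of these compounds alone.

Three amides on the shared core have been read in a functional assay on NCI-H460 cells (Homo sapiens) for inhibition, read by colorimetric assay and sulforhodamine B assay, with a stated time of 48 h (a lower number here means a stronger inhibitor of growth, a higher number a weaker inhibitor of growth), so far. Compound 1 (`CCCCCCCCCCCC[C@@H](O)[C@H]1CC[C@H]([C@H](O)CCCCCCCCCCNC(=O)c2cccs2)O1`), with thiophen-2-yl on the carbonyl carbon, gives 2290 nM there. Compound 2 (`CCCCCCCCCCCC[C@@H](O)[C@H]1CC[C@H]([C@H](O)CCCCCCCCCCNC(=O)c2ccoc2)O1`), with furan-3-yl, gives 100000 nM there. Compound 3 (`CCCCCCCCCCCC[C@@H](O)[C@H]1CC[C@H]([C@H](O)CCCCCCCCCCNC(=O)c2ccsc2)O1`), with thiophen-3-yl, gives 4900 nM and stands second highest of the three.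

Compound 4 (`CCCCCCCCCCCC[C@@H](O)[C@H]1CC[C@H]([C@H](O)CCCCCCCCCCNC(=O)c2ccnn2C)O1`) carries 1-methyl-1H-pyrazol-5-yl in place of thiophen-3-yl on a carbonyl carbon.

All three measured steps change this same group. Between the two thiophenes the series shows a 2.1-fold higher number from compound 1 to compound 3 (0.33 log units; beyond the scatter) only. The furan stands much further off, with a 44-fold higher number from compound 1 to compound 2 (1.64 log units; beyond the scatter) and a 20-fold lower number from compound 2 to compound 3 (1.31 log units; beyond the scatter) as the two gaps. The entering ring holds no sulfur, and compound 2 is the only measured case of that, at 100000 nM in a single comparison. No pyrazole has been measured, so this precedent is weak. A higher number is therefore expected in this assay with a step that is clear but smaller than the furan gap. The expected step is a 4.1-fold higher number from compound 3 to compound 4 (0.61 log units; beyond the scatter) by this estimate. The estimate for compound 4 is 20000 nM with an expected range from 4000 nM to 100000 nM in this read-out.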

Compound 4, concentration for 50% growth inhibition: 8130 nM
For compound 4 the middle estimate is 2.5-fold (0.39 log units) above the measured one, and the stated range covers the measured number.
By their numbers in this assay, from the lowest: compound 1; then compounds 3 and 4 (each within the scatter of the next); then compound 2.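

In this assay the thiophen-3-yl ring can give way to 1-methyl-1H-pyrazol-5-yl with only a 1.7-fold higher number from compound 3 to compound 4 (0.22 log units; within the scatter) as the step, so a sulfur atom in the ring on the carbonyl carbon is not needed to stay in the range of the thiophen-3-yl amide. The two rings without sulfur also stand far apart, with a 12-fold lower number from compound 2 to compound 4 (1.09 log units; beyond the scatter) as their step, so the absence of sulfur does not by itself produce the high number of the furan-3-yl amide, and that amide remains the only outlier among the four. The thiophen-2-yl amide keeps the lowest number in the series, and the new ring falls short of it, with a 3.6-fold higher number from compound 1 to compound 4 (0.55 log units; beyond the scatter) as the step.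

Nothing in the data given accounts for the distance of the furan-3-yl amide from the other three.

Open, as far as these compounds go, is whether a phenyl ring, or a thiazole ring with both nitrogen and sulfur, on the same carbonyl carbon would read with the thiophen-2-yl amide, with the two amides that sit within the scatter of each other, or with the furan-3-yl amide.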